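Ethyl ester of compound 1 on the shared core

The compounds below may be only part of what the source reports. "The series", "measured", "known", "first", "only" and "open" are said of these compounds alone.

Measured so far:
compound 1 `O=C(O)C1=Cc2ccccc2OC1(OCc1cc(-c2ccc(F)cc2)no1)C(F)(F)F` — > 150000 nM, a limit
compound 2 `O=C(O)C1=Cc2ccccc2OC1(OCc1cc(-c2ccc(F)cc2F)no1)C(F)(F)F` — > 150000 nM, a limit
compound 3 `CCOC(=O)C1=Cc2ccccc2OC1(OCc1cn(-c2cccc(C(F)(F)F)c2)nn1)C(F)(F)F` — > 150000 nM, a limit

Every value recorded in a functional assay on HeLa cells (Homo sapiens) for inhibition, read by MTT assay, with a stated time of 24 h (a higher number here means a weaker inhibitor, a lower number a stronger inhibitor), is a limit of the assay, not a number. Compound 1 stands only at the limit > 150000 nM. Compound 2 stands at the limit > 150000 nM. Compound 3 stands at the limit > 150000 nM. Among the measured compounds shown here, the one single-point step, a step that the two limits leave unreadable from compound 1 to compound 2, is therefore not readable in either direction or size. The whole evidence of the series is the limit of > 150000 nM in this assay, at which 3 of the 3 values shown sit.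

Compound 4 `CCOC(=O)C1=Cc2ccccc2OC1(OCc1cc(-c2ccc(F)cc2)no1)C(F)(F)F` differs from compound 1 by ethyl in place of hydrogen on an oxygen next to a carbonyl group. For the measured compounds named here, no measured step covers this change. Compound 3 is the only ethyl ester with a value, and it stops at the limit as well, so nothing shows that the ethoxycarbonyl group brings a reading into range.

For compound 4 the step that the limit leaves unreadable from compound 1 to compound 4 is expected to remain unreadable. Compound 4 is expected at about 200000 nM, with a range from 100000 nM to 1000000 nM, most likely reported once more as a limit.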

Compound 4, half-maximal inhibitory concentration: 42300 nM
For compound 4 the middle estimate is 4.7-fold (0.67 log units) above the measured one; measured number below the stated range.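

In this assay, among the compounds shown here, the change from carboxy to ethoxycarbonyl on the shared core gives an at least 3.5-fold lower number from compound 1 to compound 4 (0.54 log units; beyond the scatter), the first step that can be read and the first evidence that this oxygen next to a carbonyl group is a place where a change moves the reading. The value of compound 1, > 150000 nM, is a limit of the assay and not a number. The finding holds for this pair only, and compound 3, which also carries ethoxycarbonyl, goes against any wider claim: it stands at > 150000 nM, a limit.

On these data alone, whether a methyl ester, a butyl ester or a primary amide at this place also gives a number stays open, as does the same change on compound 2. The full size of the step also stays open, since the series rests mostly on limits: the limit of > 150000 nM in this assay, at which 3 of the 4 values shown sit.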